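The source may hold more compounds than are shown below. What is called first, only, known or untested is meant among the compounds shown, and "the series" means these compounds.

Compound 1 `Cc1ccc(S(=O)(=O)Nc2cccc(-c3nc(-c4ccc(NC(=O)c5cccnc5)cc4Cl)no3)c2)cc1` is the starting point. In a functional assay on MDA-MB-231 cells (Homo sapiens) for antiproliferative activity, read by MTT assay, with a stated time of 72 h (on this read-out higher numbers stand for weaker inhibition and lower numbers for stronger inhibition), compound 1 reaches only the limit of > 10000 nM, which is a limit of the measurement and not a number. Compound 2 `CC(=O)Nc1ccc(S(=O)(=O)Nc2cccc(-c3nc(-c4ccc(NC(=O)c5cccnc5)cc4Cl)no3)c2)cc1Cl` likewise stops at the limit of > 10000 nM. Compound 3 `O=C(Nc1ccc(-c2noc(-c3cccc(NS(=O)(=O)c4ccc(NC(=O)N5CCOCC5)cc4)c3)n2)c(Cl)c1)c1cccnc1` also stands at the limit of > 10000 nM. The two measured steps, a step that the two limits leave unreadable from compound 1 to compound 2 and a step that the two limits leave unreadable from compound 1 to compound 3, are therefore unreadable, as the limit of > 10000 nM in this assay, at which 3 of the 3 values shown sit, shows. Compound 4 `Cc1ccc(NC(=O)Nc2cccc(-c3nc(-c4ccc(NC(=O)c5cccnc5)cc4Cl)no3)c2)cc1` carries the change ((4-methylphenyl)carbamoyl in place of (4-methylphenyl)sulfonyl on a nitrogen on an aromatic ring), placed on a nitrogen on an aromatic ring whose other neighbour is an aromatic carbon. Going by the values given here, no measured step touches this position, so no size or direction can be read for the expected step of a number no higher from compound 1 to compound 4 (the limit leaves the size open) in this assay. Compound 4 is estimated at 10000 nM, between 3000 nM and 30000 nM.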

Compound 4, half-maximal inhibitory concentration: 3500 nM
For compound 4 the middle estimate is 2.9-fold (0.46 log units) above the measured one; the range from low to high includes it.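

In this assay, going by these compounds alone, the change on the nitrogen on an aromatic ring gives the first readable step: an at least 2.8-fold lower number from compound 1 to compound 4 (0.45 log units; beyond the scatter). So (4-methylphenyl)carbamoyl in place of (4-methylphenyl)sulfonyl shows that this position can move the read-out, whereas the steps to compound 2 and compound 3 cannot be read. The true size of this step stays open because compound 1 stands at a limit: the limit of > 10000 nM in this assay, at which 3 of the 4 values shown sit.

The compounds shown leave open whether an acetyl group or a longer alkyl chain on this nitrogen would keep the gain. They also leave open whether a morpholine-containing group on the 4-methylphenyl ring would change compound 4.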